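A phenolic amide cap in place of the carbamate

The compounds below may be only part of what the source reports. "The series", "measured", "known", "first", "only" and "open" are said of these compounds alone.

Measured so far in an ADME assay for metabolic stability; a higher number here means that the compound lasts longer, a lower number that the compound disappears faster:
Compound 1 `COC(=O)C12CC1CCN(C(=O)[C@H](CC(C)C)NC(=O)[C@H](CO)NC(=O)[C@@H](NC(=O)c1cccc(O)c1C)C(C)C)C2` gives > 6 h, a limit of the assay.
Compound 2 `COC(=O)C12CC1CCN(C(=O)[C@H](CC(C)C)NC(=O)[C@H](CO)NC(=O)[C@@H](NC(=O)C1=CCCNC1)C(C)C)C2` gives > 6 h, a limit of the assay.
Compound 3 `COC(=O)C12CC1CCN(C(=O)[C@H](CC(C)C)NC(=O)[C@H](CC(C)C)NC(=O)[C@H](CC(C)C)NC(=O)OCc1ccccc1)C2` gives > 6 h, a limit of the assay.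

Compound 3 thus stands only at a limit in this assay, with no number behind it. The change to compound 4 `COC(=O)C12CC1CCN(C(=O)[C@H](CC(C)C)NC(=O)[C@H](CC(C)C)NC(=O)[C@H](CC(C)C)NC(=O)c1cccc(O)c1C)C2` is 3-hydroxy-2-methylphenyl in place of benzyloxy on a carbonyl carbon. Within the data shown here, the only measured step, a step that the two limits leave unreadable from compound 1 to compound 2, concerns a different exchange, and its size cannot be read. Among the measured compounds shown here, because of the limit of > 6 h in this assay, at which 3 of the 3 values shown sit, no measured step yields a size or a direction for the present change. The step from compound 3 to compound 4 is therefore expected to be a step that the limit leaves unreadable from compound 3 to compound 4, most likely leaving compound 4 at the limit as well. The half-life of compound 4 is estimated at 8 h, in a range from 4 h to 20 h.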

Compound 4, half-life: > 6 h
Compound 4 gave a limit, no number; the forecaster's own chance of this, stated with the estimate: 80%; the middle value does not contradict the limit.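

No step can be read between compound 3 and compound 4, since both stand only at a limit in this assay: the limit of > 6 h in this assay, at which 4 of the 4 values shown sit.

Going by these compounds, how long these compounds actually last, and whether 3-hydroxy-2-methylphenyl in place of benzyloxy shifts the half-life at all, stays open.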